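The source may hold more compounds than are shown below. What is called first, only, known or untested is meant among the compounds shown, and "the series" means these compounds.

Measured so far:
Compound 1 `Cc1nc2c3ccccc3ccc2c2nc3c(ccc4ccccc43)c(-c3cccnc3)c12` gives 3860 nM in a functional assay on HeLa cells (Homo sapiens) for cytotoxicity, read by MTT assay, with a stated time of 48 h; a lower number here means a stronger inhibitor, a higher number a weaker inhibitor.
Compound 2 `COc1ccc(-c2c3ccc4ccccc4c3nc3c2c(C)nc2c4ccccc4ccc32)cc1` gives 45900 nM in this assay.

Going by the values given here, compound 2 stands highest of the two numbers; the only other number belongs to compound 1. Among the compounds with values here, the single measured step, a 12-fold higher number from compound 1 to compound 2 (1.08 log units; beyond the scatter), came with 4-methoxyphenyl in place of pyridin-3-yl on an aromatic carbon, so exchanging the aryl group at this carbon of the shared core moved the number far.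

Compound 3 `Cc1nc2c3ccccc3ccc2c2nc3c(ccc4ccccc43)c(-c3cc([N+](=O)[O-])ccc3N)c12` differs from compound 2 by 2-amino-5-nitrophenyl in place of 4-methoxyphenyl on an aromatic carbon. Within the data shown here, no measured step involves 2-amino-5-nitrophenyl, so the one known step bears on it only as a sign that a change of this kind can be large in either direction. Compound 3 is therefore expected to give 12000 nM in this assay, within a wide range from 2500 nM to 60000 nM. The expected step of a 3.8-fold lower number from compound 2 to compound 3 (0.58 log units; beyond the scatter) is given with low confidence.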

Compound 3, half-maximal inhibitory concentration: 5770 nM
Beside the measured number, compound 3's estimate is 2.1-fold (0.32 log units) above it; the range from low to high includes it.
By their numbers in this assay, from the lowest: compounds 1 and 3 (each within the scatter of the next); then compound 2.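

With 2-amino-5-nitrophenyl at this aromatic carbon, the step reads an 8.0-fold lower number from compound 2 to compound 3 (0.90 log units; beyond the scatter) in this assay and so shows that the high number of compound 2 goes with 4-methoxyphenyl and not with every six-membered aromatic ring of carbon only at this place. Set against pyridin-3-yl, the same group gives a 1.5-fold higher number from compound 1 to compound 3 (0.17 log units; within the scatter) and thus no separation, so the nitrogen of pyridin-3-yl is not required at this position for a number of that level.

As far as these compounds go, whether the amino group or the nitro group accounts for the difference from 4-methoxyphenyl stays open, as does how an unsubstituted phenyl, a carboxylic acid on the ring or an aminomethyl group would read at this carbon. No measurement at hand gives a reason for these steps.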